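The source may report more compounds than this note shows. Statements on the series, on what has been measured and on what is new or still open speak of the compounds shown alone.

Compound 1 `O=S(=O)(Nc1ccc(-c2nc3ccccc3o2)cc1)c1cccc(O)c1`: in an assay on cells for inhibition of HSP60/HSP10 (Homo sapiens), with a stated time of 60 min (a higher number here means a weaker inhibitor, a lower number a stronger inhibitor), compound 1 gives 62000 nM.
Compound 2 `O=S(=O)(Nc1ccc(-c2nc3ccccc3o2)cc1)c1ccccc1F`: compound 2 gives > 100000 nM, a limit of the assay.
Compound 3 `O=S(=O)(Nc1ccc(-c2nc3cc(NS(=O)(=O)c4ccccc4F)ccc3o2)cc1)c1ccccc1F`: compound 3 gives 57000 nM.

Compound 2 stands at the limit of > 100000 nM in this assay, at which 1 of the 3 values shown sits, so only a limit is known for it. Compound 4 `CCc1ccc(S(=O)(=O)Nc2ccc(-c3nc4ccccc4o3)cc2)cc1` carries 4-ethylphenyl in place of 2-fluorophenyl on a sulfonyl sulfur. Going by the values given here, two measured steps bear on this: an at least 1.6-fold higher number from compound 1 to compound 2 (0.20 log units; that floor lies within the scatter), the other change of the aryl group on the sulfonyl sulfur, and an at least 1.7-fold lower number from compound 2 to compound 3 (0.24 log units; that floor lies within the scatter), the only step that sets compound 2 against a measured number. Both have floors within the scatter, so no step beyond the scatter is expected in this assay from compound 2 to compound 4. Compound 4 is therefore estimated at 90000 nM, between 30000 nM and 300000 nM, an expected step of an at least 1.1-fold lower number from compound 2 to compound 4 (0.04 log units; that floor lies within the scatter).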

Compound 4, half-maximal inhibitory concentration: > 100000 nM
Compound 4 gave a limit, no number; the forecaster's own chance of this, stated with the estimate: 45%; at least 1.1-fold (0.04 log units) between middle value and limit.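

In this assay, 4-ethylphenyl on the sulfonyl sulfur leaves compound 4 with only a limit, as 2-fluorophenyl does for compound 2, so among these three aryl groups only the 3-hydroxyphenyl of compound 1 gives a number. That difference amounts to an at least 1.6-fold higher number from compound 1 to compound 4 (0.20 log units; that floor lies within the scatter), so it does not establish a real advantage for 3-hydroxyphenyl. The step between the two limits cannot be read: the limit of > 100000 nM in this assay, at which 2 of the 4 values shown sit.

On these data alone, whether an amine or a carboxylic acid in place of the hydroxyl of compound 1, or a longer chain in place of the ethyl of compound 4, would give a number in this assay stays open.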